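Three Tolerated Amides and an Oxazole Analogue to Come

A few compounds are considered here, and "the series" means these few. Any claim that something is new, unique, unknown or untested is made for them only; others in the source may bear on it.

Compound 1, `CCCC(=O)Nc1ncc(-c2ccc(OC)cc2)n1C`, reports only the assay limit > 100000 nM.
Compound 2, `COc1ccc(-c2cnc(NC(=O)c3cccc([N+](=O)[O-])c3)n2C)cc1`, likewise reports only the assay limit > 100000 nM.
Compound 3, `COc1cccc(-c2cnc(NC(=O)c3ccc(F)cc3)n2C)c1`, also reports only the assay limit > 100000 nM.

All three compounds were tested in a toxicity assay on THP-1 cells (Homo sapiens) for inhibition; a higher number here means that more compound is tolerated, a lower number that less compound is tolerated. For compound 1 the readout is a limit rather than a number: the cells tolerated the highest concentration tried, so the true value lies somewhere beyond what was measured. Compound 1 therefore does not stand apart from its neighbours; every measured value in this set sits at the same ceiling, as shown by the limit of > 100000 nM in this assay, at which 3 of the 3 values shown sit.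

The next compound, compound 4, `COc1ccc(-c2cnc(NC(=O)c3cnco3)n2C)cc1`, keeps the shared core of compound 1 and alters only the acyl group of the amide: 1,3-oxazol-5-yl in place of propyl on a carbonyl carbon. Among the measured compounds shown here, no pair of measured compounds in this set differs in one place, so no measured step shows how such a swap plays out in this assay.

Given that every measured value lies at the limit, the step is expected to be none beyond the usual scatter, and the estimated step of a number no higher from compound 1 to compound 4 (the limit leaves the size open) reflects that. Compound 4 is expected to give about 100000 nM, within 50000 nM to 200000 nM, most likely again reported as a limit.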

Compound 4, half-maximal cytotoxic concentration: > 100000 nM
Compound 4: only a limit was reported; the forecaster's own chance of this, stated with the estimate: 85%; the middle value sits exactly at the limit.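

In this assay compound 4 gives > 100000 nM, which is a limit and not a number. Among the compounds shown here, compound 1 also reports only a limit, so no step between compound 1 and compound 4 can be read. The compounds shown leave open at what concentration any of them would harm the cells, and whether the acyl group of the amide matters: the limit of > 100000 nM in this assay, at which 4 of the 4 values shown sit.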